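The source may hold more compounds than are shown below. What is called first, only, known or untested is meant among the compounds shown, and "the series" means these compounds.

Measured so far in a functional assay on the whole organism (arterial blood) with Rattus norvegicus as the target; on this read-out higher numbers stand for an effect only at larger amounts of compound and lower numbers for an effect already at smaller amounts
- compound 1 (`Cc1nc2cnccc2n1CC1CCN(C(=O)CC(C)c2ccccc2)CC1`) gives 0.033 mg/kg
- compound 2 (`Cc1nc2cnccc2n1CC1CCN(C(=O)CC(O)(c2ccccc2)C(F)(F)F)CC1`) gives 0.013 mg/kg
- compound 3 (`Cc1nc2cnccc2n1CC1CCN(C(=O)N[C@H](C)c2ccccc2)CC1`) gives 0.017 mg/kg

Compound 3, at 0.017 mg/kg in this assay, lies within the scatter of both compound 1 and compound 2, so it has no distinct place among the three.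

Compound 4 (`CCOC(=O)[C@H](CC(C)C)NC(=O)N1CCC(Cn2c(C)nc3cnccc32)CC1`) carries 1-(ethoxycarbonyl)-3-methylbutyl in place of 1-phenylethyl on an amide-type nitrogen. Going by the values given here, the only measured step, a 1.9-fold lower number from compound 1 to compound 3 (0.29 log units; within the scatter), puts (1-phenylethyl)amino in place of 2-phenylpropyl on a carbonyl carbon. It stays within the scatter and keeps the six-membered aromatic ring, which all three measured compounds contain. Among the compounds with values here, no measured step removes that ring, so the data give no direct size for this change. A modest move to a higher number is expected, though with little support, and the expected step is a 1.8-fold higher number from compound 3 to compound 4 (0.25 log units; within the scatter) with wide uncertainty. For compound 4 the estimate is 0.03 mg/kg, with an expected range from 0.008 mg/kg to 0.11 mg/kg.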

Compound 4, dose for 50% inhibition: 0.03 mg/kg
Compound 4: the middle estimate sits on the measured number at the digits printed; the measured number falls inside the stated range.
By their numbers in this assay, from the lowest: compounds 2, 3, 4 and 1 (each within the scatter of the next, the first and the last beyond it).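

On the amide-type nitrogen, 1-(ethoxycarbonyl)-3-methylbutyl in place of 1-phenylethyl gives a 1.8-fold higher number from compound 3 to compound 4 (0.25 log units; within the scatter) in this assay. Compound 4 is the only compound shown without a six-membered aromatic ring of carbon only in this substituent, so that ring is not required for a value within the scatter of compound 3 at this position, and the entering group's two hydrogen-bond acceptors and one double bond outside aromatic rings come with no step beyond the scatter. No available evidence bears on the reason for this result.

A single step cannot separate the contributions of the ethoxycarbonyl and 3-methylbutyl parts of the new group. As far as these compounds go, how a carboxylic acid in place of the ethyl ester, or a longer alkyl chain on the same carbon, would read remains open.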